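Capping the Phenol: From Compound 2 to Compound 3

A few compounds are considered here, and "the series" means these few. Any claim that something is new, unique, unknown or untested is made for them only; others in the source may bear on it.

Compound 1 `O=S(=O)(Nc1ccc(-c2nc3ccccc3o2)cc1)c1ccccc1Cl` — > 100000 nM (a limit of the assay, not a number)
Compound 2 `O=S(=O)(Nc1ccc(-c2nc3ccccc3o2)cc1)c1ccc(O)cc1` — 78000 nM

In an assay on cells for inhibition of HSP60/HSP10 (Homo sapiens), with a stated time of 60 min (a lower number here means a stronger inhibitor, a higher number a weaker inhibitor), compound 1 gives > 100000 nM, which is a limit of the assay rather than a measured number. Among the compounds with values here, compound 2 gives 78000 nM, the only numerical value so far, and it stands at the weak end of what the assay resolves. Within the data shown here, the single measured step, an at least 1.2-fold lower number from compound 1 to compound 2 (0.10 log units; that floor lies within the scatter), lies within the scatter, and because compound 1 sits at the limit of > 100000 nM in this assay, at which 1 of the 2 values shown sits, its size is only a floor.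

Compound 3 `COc1ccc(S(=O)(=O)Nc2ccc(-c3nc4ccccc4o3)cc2)cc1` differs from compound 2 by methyl in place of hydrogen on an oxygen on an aromatic ring. Among the measured compounds shown here, no measured step touches a substituent on the 4-hydroxyphenyl on the sulfonyl sulfur, so the only guide is that replacing the whole 2-chlorophenyl moved the number little. The step this expectation means is a 1.0-fold higher number from compound 2 to compound 3 (0.01 log units; within the scatter), essentially none beyond the scatter. Compound 3 is therefore expected to give 80000 nM, between 30000 nM and 200000 nM.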

Compound 3, half-maximal inhibitory concentration: > 100000 nM
Compound 3 gave a limit, no number; the forecaster's own chance of this, stated with the estimate: 35%; middle value at least 1.2-fold (0.09 log units) away from the limit.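

Unlike the earlier step, which replaced the whole 2-chlorophenyl, this one touches only the hydroxy of the 4-hydroxyphenyl, and methoxy in its place gave an at least 1.2-fold higher number from compound 2 to compound 3 (0.10 log units; that floor lies within the scatter). The size of that step is only a floor because compound 3 stands at a limit of the assay: the limit of > 100000 nM in this assay, at which 2 of the 3 values shown sit. In this assay, methyl on this oxygen therefore brought no gain, compound 2 remains the only one of the three with a number, and the step from compound 1 to compound 3 cannot be read, as both values are limits.

On these data alone, that floor lies within the scatter, so whether methyl on this oxygen changes anything at all stays open. Also open, as far as these compounds go, is how an amine or a carboxylic acid in place of the hydroxy, or a longer chain on the oxygen, would read in this assay.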